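Swapping the Ring on the Amine Nitrogen

The compounds below may be only part of what the source reports. "The series", "measured", "known", "first", "only" and "open" are said of these compounds alone.

Compound 1 `c1cc([C@H]2CC[C@]3(CC2)OOC2(O3)C3CC4CC(C3)CC2C4)ccc1OCC1CCNCC1` — in an ADME assay on microsomes from liver (Homo sapiens) for metabolic stability, read by LC-MS, tested at 1 uM (a higher number here means faster removal of the compound, a lower number slower removal), compound 1 gives < 7 mL.min-1.g-1, a limit of the assay.
Compound 2 `NCCCOc1ccc([C@H]2CC[C@]3(CC2)OOC2(O3)C3CC4CC(C3)CC2C4)cc1` — in this assay compound 2 gives < 7 mL.min-1.g-1, again a limit.
Compound 3 `c1cc([C@H]2CC[C@]3(CC2)OOC2(O3)C3CC4CC(C3)CC2C4)ccc1OCCCNC1CCOCC1` — in this assay compound 3 gives 10 mL.min-1.g-1.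

Going by the values given here, compound 3 therefore holds the only definite number among the three; the other two rest at the limit of < 7 mL.min-1.g-1 in this assay, at which 2 of the 3 values shown sit. Among the compounds with values here, the step of an at least 1.4-fold higher number from compound 2 to compound 3 (0.15 log units; that floor lies within the scatter) is the one measured change on the amine nitrogen, and it amounts to oxan-4-yl in place of hydrogen. The step of an at least 1.4-fold higher number from compound 1 to compound 3 (0.15 log units; that floor lies within the scatter) reshapes the whole chain and is of similar size.

Compound 4 `O[C@H]1CC[C@H](NCCCOc2ccc([C@H]3CC[C@]4(CC3)OOC3(O4)C4CC5CC(C4)CC3C5)cc2)CC1` differs from compound 3 in a single place: 4-hydroxycyclohexyl in place of oxan-4-yl on an amine nitrogen. Within the data shown here, no measured step exchanges one saturated ring for another on this nitrogen, so the measured steps give only a loose guide. With the nitrogen still carrying a six-membered ring, as in compound 3, the expected change in this assay is none beyond the scatter, and for compound 4 a step of a 1.1-fold lower number from compound 3 to compound 4 (0.05 log units; within the scatter) is estimated. Compound 4 is thus expected to give 9 mL.min-1.g-1 in this assay, within 5 mL.min-1.g-1 to 18 mL.min-1.g-1.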

Compound 4, intrinsic clearance in microsomes: < 7 mL.min-1.g-1
Compound 4 gave a limit, no number; the forecaster's own chance of this, stated with the estimate: 30%; middle value at least 1.2-fold (0.10 log units) from the limit.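

Going by these compounds alone, on the amine nitrogen, this is the first exchange of one saturated six-membered ring for another, and 4-hydroxycyclohexyl in place of oxan-4-yl gives an at least 1.4-fold lower number from compound 3 to compound 4 (0.15 log units; that floor lies within the scatter). Within the data shown here, compound 3 thus remains the only compound with a definite number, and a six-membered ring on this nitrogen does not always come with one, as compound 4 joins compounds 1 and 2 at a limit: the limit of < 7 mL.min-1.g-1 in this assay, at which 3 of the 4 values shown sit. The steps to compound 4 from compound 1 and from compound 2 have a limit at both ends and cannot be read.

From the compounds shown here alone, how far compound 4 lies under its limit stays open, so the true size of its step from compound 3 is unknown. Also open, going by these compounds, is what a plain cyclohexyl group, with no hydroxyl, would give on this amine nitrogen.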